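Lengthening the Hydroxyalkyl Ester Chain on Compound 2

The source may hold more compounds than are shown below. What is called first, only, known or untested is meant among the compounds shown, and "the series" means these compounds.

Measured compounds:
compound 1 `CC(C)=CC[C@@H](OC[C@H](C)O)C1=CC(=O)c2c(O)ccc(O)c2C1=O`: 24500 nM
compound 2 `CC[C@](C)(O)CC(=O)O[C@H](CC=C(C)C)C1=CC(=O)c2c(O)ccc(O)c2C1=O`: 20500 nM

In a functional assay on DU-145 cells (Homo sapiens) for cytotoxicity, read by MTT assay (on this read-out lower numbers stand for stronger inhibition and higher numbers for weaker inhibition), compound 1 gives 24500 nM and compound 2 gives 20500 nM. Compound 2 has the lowest of the two numbers, but the step of a 1.2-fold lower number from compound 1 to compound 2 (0.08 log units; within the scatter) is within the scatter, so the two compounds cannot be ranked against each other.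

Compound 3 `CCCCC(C)(O)CC(=O)O[C@H](CC=C(C)C)C1=CC(=O)c2c(O)ccc(O)c2C1=O` is not yet measured. It differs from compound 2 in one place: 1-hydroxy-1-methylpentyl in place of 1-hydroxy-1-methylpropyl on a saturated chain carbon bound to a carbonyl carbon. Going by the values given here, only one measured step touches this ester region, the change from compound 1 to compound 2, and it was within the scatter. No measured step tests a chain extension of this kind, so nothing in the shown data supports a shift beyond the scatter in either direction. The expected step is a 1.1-fold lower number from compound 2 to compound 3 (0.06 log units; within the scatter), and compound 3 is estimated at 18000 nM, within a range from 7000 nM to 45000 nM.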

Compound 3, half-maximal inhibitory concentration: 76500 nM
Estimate against measurement, compound 3: 4.3-fold (0.63 log units) below; measured number above the stated range.
By their numbers in this assay, from the lowest: compounds 2 and 1 (each within the scatter of the next); then compound 3.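

In this assay the ester region proves sensitive to the chain: 1-hydroxy-1-methylpentyl in place of 1-hydroxy-1-methylpropyl on a saturated chain carbon bound to a carbonyl carbon gives a 3.7-fold higher number from compound 2 to compound 3 (0.57 log units; beyond the scatter) and so, unlike the earlier step in this region, lies beyond the scatter. Set against the 2-hydroxypropyl compound, (2-hydroxy-2-methylhexyl)carbonyl on an oxygen on a saturated carbon gives a 3.1-fold higher number from compound 1 to compound 3 (0.49 log units; beyond the scatter) and thus also stands beyond the scatter, which places compound 3 apart from both earlier compounds. Nothing available explains this difference.

With only one extension shown, it remains open whether the number keeps rising with chain length or whether this step is particular to 1-hydroxy-1-methylpentyl. Also open, as far as these compounds go, is how 1-hydroxy-1-methylethyl, an amine or a carboxylic acid would read in that place.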